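A few compounds are considered here, and "the series" means these few. Any claim that something is new, unique, unknown or untested is made for them only; others in the source may bear on it.

Of the compounds shown here, three have so far been measured in an in vivo ADME assay on the whole organism (strain Sprague-Dawley) for pharmacokinetics, with Rattus norvegicus as the target; on this read-out higher numbers stand for wider distribution into tissues and lower numbers for narrower distribution. Compound 1 (`CN[C@@H](C)c1ccc(N2CC[C@H](NS(=O)(=O)c3ccc4cc(Cl)ccc4c3)C2=O)c(F)c1`) gives 2.4 L/kg and compound 2 (`CN(C)[C@H]1CCc2cc(N3CC[C@H](NS(=O)(=O)c4ccc5cc(Cl)ccc5c4)C3=O)ccc21`) gives 2 L/kg. These two numbers lie within the usual scatter of repeated measurements, so they count as level. Compound 3 (`CN1CCCC1c1ccc(N2CC[C@H](NS(=O)(=O)/C=C/c3ccc(Cl)s3)C2=O)c(F)c1`) gives 0.8 L/kg, and its gap from compound 1 lies beyond that scatter, which puts compound 1 at the upper end of this small set, level with compound 2.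

Compound 4 (`O=C1[C@@H](NS(=O)(=O)c2ccc3cc(Cl)ccc3c2)CCN1c1ccc([C@H]2CCCN2)cc1F`) has not yet been measured. It keeps the core of compound 1 and changes one group: pyrrolidin-2-yl in place of 1-(methylamino)ethyl on an aromatic carbon. The place of the change is meta to a fluoro group and para to a large group, and what enters brings one five-membered non-aromatic ring.

For the measured compounds named here, no two measured compounds differ in just one place, so the data offer no direct guide to the size of this change. The expectation is therefore no step beyond the scatter in this assay, in either direction, starting from compound 1 at 2.4 L/kg. The expected change is small, a 1.1-fold lower number from compound 1 to compound 4 (0.04 log units; within the scatter). For compound 4 the estimated value is 2.2 L/kg, with an expected range from 1.2 L/kg to 4 L/kg.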

Compound 4, volume of distribution at steady state: 1.9 L/kg
Compound 4: the middle estimate sits 1.2-fold (0.06 log units) above what was measured; low and high end bracket the measured number.
By their numbers in this assay, from the lowest: compound 3; then compounds 4, 2 and 1 (each within the scatter of the next).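

In this assay, for the compounds shown here, compounds 1 and 4 form the first pair that differs in only one place, and this gives a direct reading of a single change: there is a 1.3-fold lower number from compound 1 to compound 4 (0.10 log units; within the scatter) when pyrrolidin-2-yl takes the place of 1-(methylamino)ethyl on the aromatic carbon. Going by these compounds alone, at this place, meta to a fluoro group and para to a large group, a group with no ring and a group with one five-membered non-aromatic ring therefore count as level on this read-out, so the ring brings no measurable step here. No measurement shown gives a reason for this result.

Within the data shown here, this single pair covers only two closely matched groups at this place, so it remains open whether a carboxylic acid, a tertiary amine such as dimethylamino, or a longer chain would also stay level in this assay. As far as these compounds go, it also remains open whether the same swap would behave in the same way with a different group on the sulfonamide, or without the fluoro group on the aromatic ring.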